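A Third Aryl Group on the Shared Core

A few compounds are considered here, and "the series" means these few. Any claim that something is new, unique, unknown or untested is made for them only; others in the source may bear on it.

Measured so far:
compound 1 `Cc1cc(=O)n(-c2ccccc2C(F)(F)F)nc1C(=O)Nc1ccc(Oc2ncnc3ccsc23)cc1` gives 8850 nM
compound 2 `Cc1cc(=O)n(-c2ccc(Br)cc2F)nc1C(=O)Nc1ccc(Oc2ncnc3ccsc23)cc1` gives 7930 nM

Both numbers come from a functional assay on A549 cells (Homo sapiens) for cytotoxicity, read by MTT assay, with a stated time of 72 h; on this read-out higher numbers stand for weaker inhibition and lower numbers for stronger inhibition. Compound 2 has the smaller of the two numbers, but a 1.1-fold lower number from compound 1 to compound 2 (0.05 log units; within the scatter) places that gap within the scatter, so compound 2 and compound 1 cannot be told apart on this read-out. Compound 3 `Cc1cc(=O)n(-c2ccccc2OC(F)(F)F)nc1C(=O)Nc1ccc(Oc2ncnc3ccsc23)cc1` has not been measured. It differs from compound 2 in one place: 2-(trifluoromethoxy)phenyl in place of 4-bromo-2-fluorophenyl on an aromatic nitrogen. For the measured compounds named here, the only measured step that bears on this, a change of the same aryl group on the same aromatic nitrogen, is a 1.1-fold lower number from compound 1 to compound 2 (0.05 log units; within the scatter), which did not move the number beyond the scatter. With nothing else to draw on, the expected step of a 1.1-fold higher number from compound 2 to compound 3 (0.03 log units; within the scatter) is none beyond the scatter, in no particular direction. Compound 3 is therefore estimated at 8500 nM, with a range from 4000 nM to 18000 nM.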

Compound 3, half-maximal inhibitory concentration: 10100 nM
Estimate against measurement, compound 3: 1.2-fold (0.07 log units) below, within the range that was stated.
By their numbers in this assay, from the lowest: compounds 2, 1 and 3 (each within the scatter of the next).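

For the compounds shown here, neither new step separates compound 3 from the earlier compounds in this assay: 2-(trifluoromethoxy)phenyl in place of 4-bromo-2-fluorophenyl gives a 1.3-fold higher number from compound 2 to compound 3 (0.11 log units; within the scatter) on the aromatic nitrogen, and trifluoromethoxy in place of trifluoromethyl gives a 1.1-fold higher number from compound 1 to compound 3 (0.06 log units; within the scatter) on the aromatic carbon. The second step is the closer comparison, and it shows that this exchange of one fluorinated group for another leaves no readable mark on this read-out, while all three aryl groups tried on this nitrogen stay within the scatter of one another. No measurement is available to account for this flat result.

The compounds shown leave open whether this nitrogen would respond to a different kind of group, such as a phenyl ring carrying an amine or a carboxylic acid, or a longer alkyl chain in place of the aryl ring. They also leave open whether replacing the methyl group on the shared core would move the number beyond the scatter.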